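This account rests on a few compounds, and the source may have more. Where it says the series, first, only, none or still open, it means among the compounds named here.

Measured compounds:
compound 1 `CCCSc1nc(N[C@@H]2C[C@H]2c2ccc(F)c(F)c2)c2nnn([C@@H]3C[C@H](OCCOC(=O)OCC)[C@@H](O)[C@H]3O)c2n1` — 47.7%
compound 2 `CCCSc1nc(N[C@@H]2C[C@H]2c2ccc(F)c(F)c2)c2nnn([C@@H]3C[C@H](OC(=O)c4ccccc4)[C@@H](O)[C@H]3O)c2n1` — 20.1%

For the measured compounds named here, in a functional assay on the whole organism (strain Sprague-Dawley) for inhibition, with Rattus norvegicus as the target, with a stated time of 0.5 h, at a dose of 5 mg/kg by the oral route (on this read-out lower numbers stand for less inhibition and higher numbers for more inhibition at the one dose given (going by the name of the read-out)), compound 2 gives the lower of the two numbers, and the one step connecting the two compounds was a number 27.6 percentage points lower from compound 1 to compound 2 (beyond the scatter). Compound 3 `CCCSc1nc(N[C@@H]2C[C@H]2c2ccc(F)c(F)c2)c2nnn([C@@H]3C[C@H](OCCOC(=O)c4cccnc4)[C@@H](O)[C@H]3O)c2n1` differs from compound 2 by 2-(((pyridin-3-yl)carbonyl)oxy)ethyl in place of benzoyl on an oxygen on a saturated carbon. Going by the values given here, the only step that bears on this change is the one from compound 1 to compound 2, where the chain-linked ester gave the higher number, so the change to compound 3 is expected to move in the opposite direction, a rise beyond the scatter. Compound 3 is therefore estimated at 40%, between 20% and 60%, an expected step of a number 19.9 percentage points higher from compound 2 to compound 3 (beyond the scatter).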

Compound 3, a percentage reported as inhibition, in the whole organism at one dose (the size of the read-out at that dose, not a potency): "not active" (no number reported)
The entry for compound 3 holds no number, and the estimate cannot be compared.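

For the compounds shown here, compound 3 is reported as "not active" with no number, so no step from compound 2 to compound 3 can be read. On these data alone, how far 2-(((pyridin-3-yl)carbonyl)oxy)ethyl differs from benzoyl in effect stays open, and no evidence at hand bears on this result.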